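The source may hold more compounds than are shown below. What is called first, only, known or untested is meant among the compounds shown, and "the series" means these compounds.

Compound 1, `OC[C@]1(c2cccc(F)c2)NC[C@H](O)[C@H]1O`, was tested in an assay on isolated protein for inhibition of alpha-mannosidase (Canavalia ensiformis), tested at 1000 uM (a lower number here means less inhibition, a higher number more inhibition at the concentration tested (going by the name of the read-out)), and gave 0%. Compound 3, `OC[C@@]1(c2c(F)c(F)c(F)c(F)c2F)NC[C@@H](O)[C@@H]1O`, is the nearest neighbour on the numbers: in this assay compound 3 gives 0%, the same figure as compound 1 at the digits shown. The furthest of the three is compound 2, `CCCC[C@]1(CO)NC[C@@H](O)[C@@H]1O`, which in this assay gives 1.9%; even this gap lies within the usual scatter of repeated measurements, so none of the three compounds can be told apart on these data, and all show very little inhibition at the concentration tested.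

The next compound, compound 4, `COc1cccc([C@@]2(CO)NC[C@H](O)[C@H]2O)c1`, differs from compound 1 in one place: methoxy in place of fluoro on an aromatic carbon. Within the data shown here, no pair of measured compounds with a difference in a single place has been measured here, so there is no step to lean on. Because all three measured numbers cluster low and compound 1 reads 0%, the step from compound 1 to compound 4 is expected to be no change at the digits printed from compound 1 to compound 4 (within the scatter), that is, no change beyond the scatter. Compound 4 is therefore expected to give 0% in this assay, in a range from 0% to 10%.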

Compound 4, a percentage reported as inhibition, at one concentration (the size of the read-out at that concentration, not a potency): 0%
Beside the measured number, compound 4's estimate shows no gap at the digits printed; the range from low to high includes it.
By their numbers in this assay, from the lowest: compounds 1, 3, 4 and 2 (each within the scatter of the next).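

In this assay, among these compounds, methoxy in place of fluoro on an aromatic carbon gives no change at the digits printed from compound 1 to compound 4 (within the scatter), the only step here between two compounds that differ in one place. Methoxy brings a hydrogen-bond acceptor, yet at this position the reading does not move apart from that of fluoro. The step starts from compound 1 at 0%, which leaves no room to see a loss, so it shows only that methoxy does not lift the reading beyond the scatter, not that the position is unimportant.

No measurement here offers an explanation for this result. Still open, as far as these compounds go, is whether an amine, a carboxylic acid or a longer chain on this aromatic carbon would produce clear inhibition of the enzyme.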